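A few compounds are considered here, and "the series" means these few. Any claim that something is new, unique, unknown or untested is made for them only; others in the source may bear on it.

Compound 2 `CCC(CC)OC(=O)C1=C(C)NC(=O)NC1c1ccsc1` stands lowest of the two numbers in an assay on membranes from CHO cells for displacement of a labelled ligand from adenosine receptor A1 (Homo sapiens), read by scintillation counting, with a stated time of 60 min, tested at 1 uM (a lower number here means less inhibition, a higher number more inhibition at the concentration tested (going by the name of the read-out)), with compound 2 giving 22%; compound 1 `CCCOC(=O)C1=C(C)NC(=O)NC1c1ccsc1` gives 44%. Among the compounds with values here, the one measured step is a number 22 percentage points lower from compound 1 to compound 2 (beyond the scatter). Compound 3 `CC1=C(C(=O)OCC2CCC2)C(c2ccsc2)NC(=O)N1` differs from compound 2 by cyclobutylmethyl in place of pentan-3-yl on an oxygen next to a carbonyl group. The measured step bears on it only loosely, since both groups entering here carry five carbons and the change is in shape rather than size; the step from compound 2 to compound 3 in this assay is expected to be small, a number 8 percentage points higher from compound 2 to compound 3 (within the scatter), close to the scatter. Compound 3 is thus estimated at 30%, within 15% to 48%.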

Compound 3, a percentage reported as inhibition, at one concentration (the size of the read-out at that concentration, not a potency): 48%
Beside the measured number, compound 3's estimate is 18 percentage points below it, and the stated range covers the measured number.
By their numbers in this assay, from the lowest: compound 2; then compounds 1 and 3 (each within the scatter of the next).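

In this assay, holding five carbons on an oxygen next to a carbonyl group does not by itself set the level of inhibition: cyclobutylmethyl in place of pentan-3-yl gives a number 26 percentage points higher from compound 2 to compound 3 (beyond the scatter) with the carbon count unchanged. Cyclobutyl in place of ethyl on the saturated chain carbon gives a number 4 percentage points higher from compound 1 to compound 3 (within the scatter) and so leaves compound 3 and compound 1 indistinguishable in this read-out. No measured information bears on the origin of these steps.

From the compounds shown here alone, whether a longer chain, an amine or a carboxylic acid at this oxygen retains inhibition remains open. Potency is also open, since each number comes from a single concentration.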